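Benzyl for bromo on the anilide ring: expected potency

The source may report more compounds than this note shows. Statements on the series, on what has been measured and on what is new or still open speak of the compounds shown alone.

Measured compounds in an assay on isolated protein for inhibition of Indoleamine 2,3-dioxygenase 1 (Homo sapiens), read by spectrophotometry; on this read-out higher numbers stand for weaker inhibition and lower numbers for stronger inhibition:
compound 1 `O/N=C(/Nc1cccc(F)c1)c1ccc2occc2c1` gives 32700 nM
compound 2 `O/N=C(/Nc1cccc(Br)c1)c1ccc2occc2c1` gives 440 nM
compound 3 `O/N=C(/Nc1ccc(F)c(Br)c1)c1ccc2occc2c1` gives 1600 nM

Compound 2 gives the lowest number of the three in this assay. Its nearest neighbour is compound 3, reached by a 3.6-fold higher number from compound 2 to compound 3 (0.56 log units; beyond the scatter); the furthest is compound 1, from which compound 2 is reached by a 74-fold lower number from compound 1 to compound 2 (1.87 log units; beyond the scatter).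

Compound 4 `O/N=C(/Nc1cccc(Cc2ccccc2)c1)c1ccc2occc2c1` is not yet measured. It differs from compound 2 by benzyl in place of bromo on an aromatic carbon.

Neither measured step is the same change. The step from compound 1 to compound 2 shows that this position answers strongly to a change of substituent, while the step from compound 2 to compound 3 shows a modest loss when a second substituent is added. Going by the values given here, no measured step exchanges a halogen for a benzyl, so the direction is open; a step of modest size in this assay, more likely toward a higher number, is expected as a 3.4-fold higher number from compound 2 to compound 4 (0.53 log units; beyond the scatter).

Compound 4 is therefore estimated at 1500 nM, within a range of 200 nM to 12000 nM.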

Compound 4, half-maximal inhibitory concentration: > 30000 nM
Compound 4: no number, only a limit; the forecaster's own chance of this, stated with the estimate: 5%; at least 20-fold (1.30 log units) between middle value and limit.
By their numbers in this assay, from the lowest: compound 2; then compound 3; then compound 1.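

In this assay compound 4 gives > 30000 nM, a limit of the assay and not a number: the limit of > 30000 nM in this assay, at which 1 of the 4 values shown sits. Benzyl in place of bromo gives an at least 68-fold higher number from compound 2 to compound 4 (1.83 log units; beyond the scatter), so the gain on going from fluoro to bromo, a 74-fold lower number from compound 1 to compound 2 (1.87 log units; beyond the scatter), does not carry over to this much larger group, and this position does not simply reward a bigger substituent. The step from compound 1 to compound 4 cannot be read against the limit, so fluoro and benzyl cannot be ranked at this place.

From the compounds shown here alone, it remains open whether the loss comes with any group larger than bromo or is particular to benzyl. A methyl, a methoxy or a directly attached phenyl at this place would narrow that question, and an amine would extend it beyond carbon and halogen groups.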